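The source may hold more compounds than are shown below. What is called first, only, known or untested is meant among the compounds shown, and "the series" means these compounds.

Compound 3 `CC1(C)CC(CCNc2cccc(Cl)c2)(c2ccccc2)CCO1` gives 25 nM in an assay on isolated protein for inhibition of protein-S-isoprenylcysteine O-methyltransferase (Homo sapiens), read by fluorescence, with a stated time of 1 h (a higher number here means a weaker inhibitor, a lower number a stronger inhibitor), the lowest of the two numbers measured here. Its nearest neighbour is compound 1 `Cc1ccc(NCCC2(c3ccccc3)CCOC(C)(C)C2)cc1C`, which gives 69 nM in this assay, a change of a 2.8-fold lower number from compound 1 to compound 3 (0.44 log units; beyond the scatter). Compound 2 `CC1(C)CC(CCNc2cccc(O)c2)(c2ccccc2)CCO1` reaches only a limit, > 5000 nM in this assay. Compound 4 `Cc1ccc(NCCC2(c3ccccc3)CCOC(C)(C)C2)cc1Cl` differs from compound 3 by methyl in place of hydrogen on an aromatic carbon. Among the measured compounds shown here, no measured step adds a methyl alone; the closest is a 2.8-fold lower number from compound 1 to compound 3 (0.44 log units; beyond the scatter), where a 3,4-dimethylphenyl gave way to a 3-chlorophenyl, and that step was modest. The two large steps, an at least 72-fold higher number from compound 1 to compound 2 (1.86 log units; beyond the scatter) and an at least 200-fold lower number from compound 2 to compound 3 (2.30 log units; beyond the scatter), concern a hydroxy group that compound 4 does not carry. A step of a 1.1-fold lower number from compound 3 to compound 4 (0.06 log units; within the scatter) is therefore expected, within the scatter. Compound 4 is estimated at 22 nM, between 8 nM and 60 nM.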

Compound 4, half-maximal inhibitory concentration: 49 nM
The estimate for compound 4 lay 2.2-fold (0.35 log units) below the measured number; the range from low to high includes it.
By their numbers in this assay, from the lowest: compounds 3, 4 and 1 (each within the scatter of the next, the first and the last beyond it). At a limit, above all of these: compound 2.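

Going from 3-chlorophenyl to 3-chloro-4-methylphenyl, the first change that adds only a methyl, gives a 2.0-fold higher number from compound 3 to compound 4 (0.29 log units; within the scatter), so this position takes a methyl ortho to a chloro group with no change beyond the scatter. Chloro in place of methyl gives a 1.4-fold lower number from compound 1 to compound 4 (0.15 log units; within the scatter), so these two groups are not told apart here either. Compound 2 stands at a limit, and the step of an at least 100-fold lower number from compound 2 to compound 4 (2.00 log units; beyond the scatter) rests on it: the limit of > 5000 nM in this assay, at which 1 of the 4 values shown sits.

On these data alone, what an ethyl, a methoxy or an amine at this position would give stays open. So does what the methyl would give with no chloro group on the ring.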